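Aryl variation on the benzyl ether of the shared core

The source may report more compounds than this note shows. Statements on the series, on what has been measured and on what is new or still open speak of the compounds shown alone.

Measured so far:
compound 1 `CC(C)(N)C(=O)N[C@H](COCc1cc(Cl)cc(Cl)c1)c1nnnn1CCOC(=O)NCCCCO`, 6.75 nM
compound 2 `CC(C)(N)C(=O)N[C@H](COCc1ccc(OC(F)(F)F)cc1)c1nnnn1CCOC(=O)NCCCCO`, 33.2 nM

In a functional assay on cells for inhibition of growth hormone secretagogue receptor type 1 (Homo sapiens), read by FLIPR and calcium flux (on this read-out higher numbers stand for an effect only at larger amounts of compound and lower numbers for an effect already at smaller amounts), compound 2 gives 33.2 nM, the higher of the two numbers; compound 1 gives 6.75 nM. For the measured compounds named here, the one measured step, a 4.9-fold higher number from compound 1 to compound 2 (0.69 log units; beyond the scatter), swaps the aryl group on the benzyl ether and is beyond the scatter.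

Compound 3 `Cc1ccccc1COC[C@@H](NC(=O)C(C)(C)N)c1nnnn1CCOC(=O)NCCCCO` is not yet measured. It differs from compound 2 as 2-methylphenyl in place of 4-(trifluoromethoxy)phenyl on a saturated chain carbon bound to an oxygen on a saturated carbon. Going by the values given here, only the step from compound 1 to compound 2 bears on this change, and it shows that exchanging the aryl group at this place can move the number by a modest amount in either direction. Among the compounds with values here, no measured pair shows a small aryl group without a second substituent here, so the direction for compound 3 is uncertain. For compound 3 a small step, within the scatter or slightly beyond it, is expected, and the estimated change is a 1.4-fold higher number from compound 2 to compound 3 (0.13 log units; within the scatter).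

Compound 3 is estimated at 45 nM, with a range from 12 nM to 180 nM.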

Compound 3, half-maximal effective concentration: 0.51 nM
Compound 3: middle estimate off by 88-fold (1.95 log units), on the high side, and the stated range ends above it.
By their numbers in this assay, from the lowest: compound 3; then compound 1; then compound 2.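

In this assay, for the compounds shown here, the step to 2-methylphenyl, a 65-fold lower number from compound 2 to compound 3 (1.81 log units; beyond the scatter), is large, whereas the only earlier step at this place was modest. The same exchange also gives a 13-fold lower number from compound 1 to compound 3 (1.12 log units; beyond the scatter), so 2-methylphenyl goes beyond both earlier aryl groups towards a lower number, and this aryl group on the saturated chain carbon bound to an oxygen can shift the read-out much further than the first pair indicated. No measurement or other evidence here accounts for the size of these steps.

No pair shown separates the effect of the methyl group itself from that of its place on the aryl ring. Plain phenyl would test the first point, and an ethyl or methoxy group in place of the methyl would show how far this result extends.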